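This account rests on a few compounds, and the source may have more. Where it says the series, first, only, none or still open, it means among the compounds named here.

Four compounds share one core and differ only in the group carried on a saturated ring carbon of a six-membered non-aromatic ring with one nitrogen. Compound 1 `CN(C)C(=O)C1CCN(c2nc(-c3cc(F)c(Cl)cc3F)nc3c2CS(=O)(=O)C3)CC1` carries dimethylcarbamoyl there. In a physicochemical assay for solubility, with a stated time of 20 h, at pH 6.8 (on this read-out lower numbers stand for lower solubility and higher numbers for higher solubility), compound 1 reaches only a limit of the measurement, > 100000 nM, so no number is known for it. Compound 2 `O=S1(=O)Cc2nc(-c3cc(F)c(Cl)cc3F)nc(N3CCC(CO)CC3)c2C1` carries hydroxymethyl, and in this assay compound 2 gives 16000 nM. Going by the values given here, compound 3 `NC(=O)C1CCN(c2nc(-c3cc(F)c(Cl)cc3F)nc3c2CS(=O)(=O)C3)CC1` carries carbamoyl, and in this assay compound 3 gives 40000 nM, the higher of the two known numbers, with a 2.5-fold higher number from compound 2 to compound 3 (0.40 log units; beyond the scatter). Compound 1 cannot be placed in this order because compound 1 sits at the limit of > 100000 nM in this assay, at which 1 of the 3 values shown sits.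

Compound 4 `O=S1(=O)Cc2nc(-c3cc(F)c(Cl)cc3F)nc(N3CCC(O)CC3)c2C1` is compound 3 with hydroxy in place of carbamoyl on a saturated ring carbon. Among the compounds with values here, two measured steps bear on this change: a 2.5-fold higher number from compound 2 to compound 3 (0.40 log units; beyond the scatter), which read backwards shows a carbamoyl giving way to a hydroxyl-bearing group, and an at least 6.2-fold lower number from compound 1 to compound 2 (0.79 log units; beyond the scatter), where a hydroxymethyl also gave a lower number than an amide. A modest fall is therefore expected, a 2.7-fold lower number from compound 3 to compound 4 (0.43 log units; beyond the scatter). Compound 4 is estimated to give 15000 nM, within a range from 5000 nM to 45000 nM.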

Compound 4, solubility: 91000 nM
The estimate for compound 4 lay 6.1-fold (0.78 log units) below the measured number; the measured number lies above the stated range.
By their numbers in this assay, from the lowest: compound 2; then compound 3; then compound 4. At a limit, above all of these: compound 1.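

At this ring carbon, three ring bonds from the ring nitrogen, a hydroxyl-bearing group does not in itself go with a low number in this assay. Hydroxy in place of carbamoyl on a saturated ring carbon gives a 2.3-fold higher number from compound 3 to compound 4 (0.36 log units; beyond the scatter). Hydroxy in place of hydroxymethyl gives a larger change, a 5.7-fold higher number from compound 2 to compound 4 (0.75 log units; beyond the scatter), so two groups that both end in a hydroxyl sit at opposite ends of the known numbers. Hydroxy in place of dimethylcarbamoyl gives an at least 1.0-fold lower number from compound 1 to compound 4 (0.04 log units; that floor lies within the scatter). No order can be read from this step, because compound 1 stands at a limit of the measurement: the limit of > 100000 nM in this assay, at which 1 of the 4 values shown sits.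

From the compounds shown here alone, it remains open whether the hydroxyl on the ring carbon or the shorter group matters more. An amine, a methoxy group or a longer chain such as hydroxyethyl at this carbon could help to separate the two.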